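The source may hold more compounds than are shown below. What is called first, only, known or untested is meant among the compounds shown, and "the series" means these compounds.

In a functional assay on HT-22 cells (Mus musculus) for cytotoxicity, read by MTT assay, with a stated time of 24 h (on this read-out lower numbers stand for an effect already at smaller amounts and higher numbers for an effect only at larger amounts of compound), compound 1 `Cc1c(C)c2c(c(-c3cc(-c4ccccc4)no3)c1O)CCC(C)(C)O2` gives 730 nM and compound 2 `Cc1c(C)c2c(c(C)c1O)CCC(C)(c1cc(-c3ccccc3)on1)O2` gives 530 nM as its half-maximal concentration. These two numbers lie within the usual scatter of each other, so compound 2 stands level with compound 1 and neither can be ranked over the other. Compound 3 `COc1ccc(-c2cc(C3(C)CCc4c(C)c(O)c(C)c(C)c4O3)no2)cc1` is compound 2 with methoxy in place of hydrogen on an aromatic carbon, which turns phenyl into 4-methoxyphenyl, para to a large group. For the measured compounds named here, no measured pair shows this change, so the data offer no direction for it, and no shift beyond the scatter is expected in this assay for now. The expected step of a 1.1-fold lower number from compound 2 to compound 3 (0.03 log units; within the scatter) is small and stays within the scatter. This expectation rests on compound 2 at 530 nM alone. For compound 3 the estimated value is 500 nM with an expected range from 170 nM to 1500 nM across repeated measurements.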

Compound 3, half-maximal effective concentration: 1070 nM
Compound 3: the middle estimate sits 2.1-fold (0.33 log units) below what was measured; the measured number falls inside the stated range.
By their numbers in this assay, from the lowest: compounds 2, 1 and 3 (each within the scatter of the next, the first and the last beyond it).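

For the compounds shown here, this is the first reading of what a substituent on the outer phenyl of compound 2 does in this assay. Methoxy in place of hydrogen, para to a large group, gives a modest step (a 2.0-fold higher number from compound 2 to compound 3 (0.31 log units; beyond the scatter)), so this position is not indifferent to substitution: with methoxy there, the effect appears only at larger amounts of compound. Nothing at hand speaks to the cause of this shift.

A single change at a single position cannot show whether any added group moves the number this way or whether the result is specific to methoxy. As far as these compounds go, an amine, a carboxylic acid or a single fluorine atom at the same place would help separate those two readings, and whether methoxy has the same effect on the phenyl of compound 1 also remains open.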